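Ethoxy for ethyl: the step from compound 3 to compound 4

A few compounds are considered here, and "the series" means these few. Any claim that something is new, unique, unknown or untested is made for them only; others in the source may bear on it.

Three compounds share a core and have been run in a functional assay on A-375 cells (Homo sapiens) for antiproliferative activity, read by MTT assay, with a stated time of 24 h, tested at 0.14 ug/mL; on this read-out lower numbers stand for a weaker effect and higher numbers for a stronger effect at the one concentration tested. Compound 1 `CCc1ccc2nc(C(=O)Nc3c(F)cc(-c4cccc(F)c4)cc3F)c(C)c(O)c2c1` gives 1.57% in this assay. Compound 2 `Cc1ccc2nc(C(=O)Nc3c(F)cc(-c4cccc(F)c4)cc3F)c(C)c(C(=O)O)c2c1` gives 0.98%. Compound 3 `CCc1ccc2nc(C(=O)Nc3c(F)cc(-c4cccc(F)c4)cc3F)c(C)c(C(=O)O)c2c1` gives 2.45%, the highest of the three numbers, though both neighbours sit within the scatter of it: a number 0.9 percentage points higher from compound 1 to compound 3 (within the scatter) and a number 1.5 percentage points higher from compound 2 to compound 3 (within the scatter). All three numbers are small, so at this concentration none of the compounds shows a clear effect.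

Compound 4 `CCOc1ccc2nc(C(=O)Nc3c(F)cc(-c4cccc(F)c4)cc3F)c(C)c(C(=O)O)c2c1` differs from compound 3 in one place: ethoxy in place of ethyl on an aromatic carbon. Going by the values given here, no measured step swaps a chain for an oxygen-linked chain; the step from compound 2 to compound 3 touches the same chain but only lengthens it, and it stayed within the scatter, as did the step from compound 1 to compound 3 on another part of the core. On this basis the step of a number 0.1 percentage points higher from compound 3 to compound 4 (within the scatter) is expected to stay within the scatter. Compound 4 is therefore estimated at 2.5% in this assay, with a range from 0% to 12%.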

Compound 4, a percentage reported as inhibition, at one concentration (the size of the read-out at that concentration, not a potency): 3.05%
Compound 4: the middle estimate sits 0.6 percentage points below what was measured; the measured number falls inside the stated range.
By their numbers in this assay, from the lowest: compounds 2, 1, 3 and 4 (each within the scatter of the next).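

In this assay, the aromatic carbon that carries ethyl in compound 3 also accepts ethoxy, an oxygen-linked chain with one hydrogen-bond acceptor, and the step reads a number 0.6 percentage points higher from compound 3 to compound 4 (within the scatter). Going by these compounds alone, the comparison with the shorter chain gives the same reading, at a number 2.1 percentage points higher from compound 2 to compound 4 (within the scatter), so methyl, ethyl and ethoxy at this position cannot be told apart at the one concentration tested, and the earlier steps had not covered an oxygen-linked chain here. No supporting data bear on how this result should be explained.

As far as these compounds go, whether any group at this position can produce a clear effect remains open, for example an amine or a longer chain such as butoxy. Also open, from the compounds shown here alone, is whether compound 3 and compound 4 would separate at other concentrations.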